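Swapping carboxy for bromo on compound 3

The source may report more compounds than this note shows. Statements on the series, on what has been measured and on what is new or still open speak of the compounds shown alone.

Three related compounds have been measured in a functional assay on DU-145 cells (Homo sapiens) for inhibition, read by trypan blue exclusion, with a stated time of 96 h; a lower number here means a stronger inhibitor of growth, a higher number a weaker inhibitor of growth: compound 1 (`O=C(/C(=C\c1ccc([N+](=O)[O-])c(O)c1)SCc1ccc(Br)cc1)c1ccc([N+](=O)[O-])c(Cl)c1`) gives 1000 nM, compound 2 (`O=C(/C(=C\c1cc(I)c(O)c(I)c1)SCc1ccc(Br)cc1)c1ccc(Br)cc1`) gives 1000 nM, and compound 3 (`O=C(O)c1ccc(C(=O)/C(=C\c2ccc([N+](=O)[O-])c(O)c2)SCc2ccc(Br)cc2)cc1`) gives 10000 nM, the highest of the three numbers. Compound 4 (`O=C(/C(=C\c1ccc([N+](=O)[O-])c(O)c1)SCc1ccc(Br)cc1)c1ccc(Br)cc1`) departs from compound 3 by one change, bromo in place of carboxy on an aromatic carbon. For the measured compounds named here, one measured step bears on it: a 10-fold higher number from compound 1 to compound 3 (1.00 log units; beyond the scatter), a modest step that brought in the 4-carboxyphenyl group. Compound 2, which carries the 4-bromophenyl group on a differently substituted core, gives 1000 nM. A step of similar size towards a lower number is therefore expected, and the estimated step is a 10-fold lower number from compound 3 to compound 4 (1.00 log units; beyond the scatter). The estimate for compound 4 is 1000 nM, within an expected range of 300 nM to 3500 nM.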

Compound 4, concentration for 50% growth inhibition: 10000 nM
Compound 4: the middle estimate sits 10-fold (1.00 log units) below what was measured; the measured number lies above the stated range.
By their numbers in this assay, from the lowest: compounds 1 and 2 (each within the scatter of the next); then compounds 3 and 4 (each within the scatter of the next).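

In this assay, bromo in place of carboxy, para to a large group, gives no change at the digits printed from compound 3 to compound 4 (within the scatter) and so leaves the two groups level with 3-hydroxy-4-nitrophenyl on the double-bonded chain carbon. The 4-bromophenyl group therefore does not by itself give the lower number: 3-chloro-4-nitrophenyl on the carbonyl carbon is replaced with a 10-fold higher number from compound 1 to compound 4 (1.00 log units; beyond the scatter) as the result, and 4-hydroxy-3,5-diiodophenyl is replaced with a 10-fold higher number from compound 2 to compound 4 (1.00 log units; beyond the scatter) as the result.

As far as these compounds go, whether an amine or a methoxy group at this position would depart from carboxy and bromo remains open. No measurement shown accounts for these steps.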